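The source may report more compounds than this note shows. Statements on the series, on what has been measured and on what is new or still open speak of the compounds shown alone.

Among the compounds with values here, compound 1 `CCCCCNc1nn2c(=O)cc(C(F)(F)F)nc2s1` stands at the higher of the two numbers measured so far: in an assay on cells for inhibition of alkaline phosphatase, tissue-nonspecific isozyme (Homo sapiens), read by luminescence, with stated times of 7 min and 20 min (on this read-out higher numbers stand for weaker inhibition and lower numbers for stronger inhibition), compound 1 gives 610 nM. Compound 2 `Cc1cc(C)cc(-c2nn3c(=O)cc(C(F)(F)F)nc3s2)c1` lies close to it, as in this assay compound 2 gives 520 nM, a gap within the usual scatter, so the two cannot be ranked against each other. Compound 3 `O=c1cc(C(F)(F)F)nc2sc(-c3ccccc3F)nn12` has not yet been measured. Compared with compound 1 it carries 2-fluorophenyl in place of pentylamino on an aromatic carbon; in words, 2-fluorophenyl in place of pentylamino on an aromatic carbon. Within the data shown here, no measured pair shows this exact change. Compound 2, however, carries an aromatic ring of carbon only where compound 1 carries the pentylamino chain, and its number falls in the same region as that of compound 1. On that basis the step of a 1.1-fold lower number from compound 1 to compound 3 (0.04 log units; within the scatter) is expected to be small, with no direction that would stand out beyond the scatter. Compound 3 is therefore estimated at 550 nM in this assay, with an expected range from 150 nM to 2000 nM.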

Compound 3, half-maximal inhibitory concentration: > 100000 nM
Compound 3: a limit, no number; the forecaster's own chance of this, stated with the estimate: 5%; middle value at least 180-fold (2.25 log units) away from the limit.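

This position does not accept every group: in this assay, 2-fluorophenyl in place of pentylamino gives an at least 160-fold higher number from compound 1 to compound 3 (2.21 log units; beyond the scatter). Compound 3 stands at a limit, not at a number: the limit of > 100000 nM in this assay, at which 1 of the 3 values shown sits. Compound 2 also carries an aromatic ring of carbon only at this position and gives 520 nM in this assay, so such a ring on this aromatic carbon does not by itself go with the loss seen for compound 3, and the difference between the two rings and what they carry now matters.

The compounds shown leave open whether the fluorine of 2-fluorophenyl is what separates compound 3 from compound 2, a question that plain phenyl or a methylphenyl group at this position would speak to. Also open, on these data alone, is how a shorter alkylamino chain, a benzylamino group or morpholine would read in place of pentylamino, and what replacing the trifluoromethyl group, which all three compounds share, with methyl would do.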